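Sulfonyl group exchange on compound 2

The compounds below may be only part of what the source reports. "The series", "measured", "known", "first", "only" and "open" are said of these compounds alone.

In an ADME assay on the whole organism (strain Sprague-Dawley) for metabolic stability, with Rattus norvegicus as the target (a higher number here means that the compound lasts longer, a lower number that the compound disappears faster), compound 1 `CN[C@@H](C)c1ccc(N2CC[C@H](NS(=O)(=O)c3ccc4cc(Cl)ccc4c3)C2=O)c(F)c1` gives 18 h and compound 2 `O=C1[C@@H](NS(=O)(=O)/C=C/c2ccc(Cl)s2)CCN1c1ccc(C2CCCN2)cc1F` gives 3.4 h as the lower of the two numbers, with a gap beyond the scatter. These two compounds differ in more than one place, so that gap cannot be assigned to any single change. Compound 3 `O=C1[C@@H](NS(=O)(=O)c2ccc3cc(Cl)ccc3c2)CCN1c1ccc(C2CCCN2)cc1F` is derived from compound 2 through one exchange: 6-chloronaphthalen-2-yl in place of 2-(5-chlorothiophen-2-yl)ethenyl on a sulfonyl sulfur is the whole difference. Among the measured compounds shown here, no measured pair isolates this exchange. For the measured compounds named here, the only guide is compound 1 at 18 h in this assay as the one measured compound with 6-chloronaphthalen-2-yl on a sulfonyl sulfur. The rest of its structure differs from compound 3, so only part of its gap to compound 2 is expected to carry over. The expected step of a 2.1-fold higher number from compound 2 to compound 3 (0.31 log units; beyond the scatter) in this assay is an upward one of moderate size, close to the edge of the scatter. Compound 3 is expected at 7 h with an estimated range from 3.5 h to 14 h across repeat measurements.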

Compound 3, half-life: 9 h
Estimate against measurement, compound 3: 1.3-fold (0.11 log units) below; low and high end bracket the measured number.
By their numbers in this assay, from the lowest: compound 2; then compounds 3 and 1 (each within the scatter of the next).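

In this assay the exchange of 2-(5-chlorothiophen-2-yl)ethenyl for 6-chloronaphthalen-2-yl on a sulfonyl sulfur gives a 2.6-fold higher number from compound 2 to compound 3 (0.42 log units; beyond the scatter) on an otherwise unchanged structure, so this exchange now has a reading of its own, free of the second difference that kept the gap between compound 1 and compound 2 unassigned. With 6-chloronaphthalen-2-yl held fixed, pyrrolidin-2-yl in place of 1-(methylamino)ethyl on an aromatic carbon gives a 2.0-fold lower number from compound 1 to compound 3 (0.30 log units; within the scatter), so in this assay these two groups cannot be told apart, and of the two single changes only the sulfonyl exchange lies beyond the scatter. Nothing at hand accounts for the sulfonyl step, which stands as an observation only.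

On these data alone, it remains open whether the sulfonyl step carries over to the core of compound 1, as it rests on a single pair. Also open, as far as these compounds go, is where a plain naphthalen-2-yl, or a nitrile in place of the chlorine on the naphthalene, would stand in this assay relative to compound 3, and so whether the chlorine matters to the half-life at this position.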